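This account rests on a few compounds, and the source may have more. Where it says the series, first, only, none or still open, it means among the compounds named here.

Compound 1 `CS(=O)(=O)c1ccc(-c2nc3ccccn3c2Sc2ccccc2)cc1`: 72700 nM
Compound 2 `Cc1ccc(-c2nc3ccccn3c2Sc2ccccc2)cc1`: > 100000 nM

Both compounds were tested in a functional assay on MDA-MB-231 cells (Homo sapiens) for inhibition, read by MTT assay, with a stated time of 48 h; a lower number here means a stronger inhibitor, a higher number a weaker inhibitor. Compound 2 reads > 100000 nM, which is a limit of the assay and not a number. Its standing is therefore only partly known: the limit of > 100000 nM in this assay, at which 1 of the 2 values shown sits.

Compound 3 `COc1ccc(-c2nc3ccccn3c2Sc2ccccc2)cc1` keeps the rest of compound 2 and changes one group: methoxy in place of methyl on an aromatic carbon. In words, this puts methoxy in place of methyl on an aromatic carbon. Among the measured compounds shown here, one measured step bears on this carbon, and it also involves a methyl group: an at least 1.3-fold higher number from compound 1 to compound 2 (0.13 log units; that floor lies within the scatter). For the measured compounds named here, with only that small step to go on, no change beyond the scatter is expected in this assay. The expected change is an at least 1.1-fold lower number from compound 2 to compound 3 (0.04 log units; that floor lies within the scatter), an estimate set against a limit rather than a number. For compound 3 the estimated value is 90000 nM, with an expected range from 45000 nM to 150000 nM.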

Compound 3, half-maximal inhibitory concentration: > 100000 nM
Compound 3 was reported as a limit; the forecaster's own chance of this, stated with the estimate: 55%; at least 1.1-fold (0.04 log units) between middle value and limit.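

Compound 3 reads > 100000 nM in this assay, a limit of the assay and not a number, so methoxy, like methyl, yields no measured value on this aromatic carbon. Methoxy in place of methylsulfonyl gives an at least 1.3-fold higher number from compound 1 to compound 3 (0.13 log units; that floor lies within the scatter), while the step between compound 2 and compound 3 cannot be read. Among these three compounds, only methylsulfonyl has given an actual number at this position, and the other two readings now share one limit: the limit of > 100000 nM in this assay, at which 2 of the 3 values shown sit.

As far as these compounds go, it remains open how far compound 2 and compound 3 really lie past that limit, and whether methylsulfonyl truly differs from either of them. An amine or a carboxylic acid in the same place could show whether any group here gives a number clearly beyond the scatter from compound 1.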